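From a phenol to a chloroarene on a shared core

The source may hold more compounds than are shown below. What is called first, only, known or untested is meant among the compounds shown, and "the series" means these compounds.

Two measured compounds share one core and differ only on the aryl ring that carries the carbonyl. Compound 1 `COc1ccc(C(=O)/C=C/c2cc3ccccc3[nH]c2=O)cc1` carries a methoxy group there; in a functional assay on SK-MEL-2 cells (Homo sapiens) for cytotoxicity, read by sulforhodamine B assay, with a stated time of 24 h (on this read-out lower numbers stand for stronger inhibition of growth and higher numbers for weaker inhibition of growth), compound 1 gives 3910 nM. Compound 2 `O=C(/C=C/c1cc2ccccc2[nH]c1=O)c1ccc(O)cc1` carries the free hydroxy group, and in this assay compound 2 gives 4130 nM. The step of a 1.1-fold higher number from compound 1 to compound 2 (0.02 log units; within the scatter) is within the scatter. On the numbers shown, compound 2 sits at the top of a pair whose two values lie within the scatter of each other, so no real separation from compound 1 is shown.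

Compound 3 `O=C(/C=C/c1cc2ccccc2[nH]c1=O)c1ccc(Cl)cc1` is the unmeasured member. It differs from compound 2 by chloro in place of hydroxy on an aromatic carbon. Within the data shown here, no measured step bears on this change: the one step available exchanges methyl for hydrogen on the oxygen and stays within the scatter, which says nothing about removing the oxygen and putting chlorine in its place. Among the measured compounds shown here, with no bearing step, compound 3 is expected to land near compound 2 in this assay. The implied step a 1.2-fold lower number from compound 2 to compound 3 (0.07 log units; within the scatter) is expected to stay within the scatter. Compound 3 is therefore estimated at 3500 nM, with a range from 1400 nM to 9000 nM.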

Compound 3, concentration for 50% growth inhibition: 8550 nM
Estimate against measurement, compound 3: 2.4-fold (0.39 log units) below; the measured number falls inside the stated range.
By their numbers in this assay, from the lowest: compounds 1 and 2 (each within the scatter of the next); then compound 3.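

In this assay, among these compounds, the aromatic carbon para to a large group proves not to be indifferent to what it carries: the step of a 2.1-fold higher number from compound 2 to compound 3 (0.32 log units; beyond the scatter) is the first here to lie beyond the scatter, though it is only modest. The step of a 2.2-fold higher number from compound 1 to compound 3 (0.34 log units; beyond the scatter) is also modest and beyond the scatter, so the two compounds with an oxygen on this carbon stay within the scatter of each other, while compound 3, with chloro, stands apart on the side of weaker inhibition of growth. No supporting measurement accompanies these numbers, so the shift remains without an explanation.

The compounds shown cannot separate an effect of chlorine itself from that of having no oxygen on this carbon, and a fluoro group, an amine or a carboxylic acid in the same place would be needed to begin telling these apart. They also leave open whether the change from 4-hydroxyphenyl to 4-chlorophenyl would give a step of similar size on another cell line or with the group elsewhere on the ring.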